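The compounds below may be only part of what the source reports. "The series", "measured", "known", "first", "only" and "open" are said of these compounds alone.

Measured in a functional assay on cells (Homo sapiens) for inhibition; on this read-out higher numbers stand for weaker inhibition of growth and lower numbers for stronger inhibition of growth:
- compound 1 `COc1ccc(-n2cnnc2-c2cc(OC)c(OC)c(OC)c2)cc1`: 3160 nM
- compound 2 `COc1ccc(-n2cnnc2-c2cc(OC)c(OC)c(OC)c2)cc1O`: 977 nM

Not yet measured:
- compound 3 `COc1ccc(-n2cnnc2-c2cc(OC)c(OC)c(OC)c2)cc1F`

Compound 2 has the lower number of the two measured compounds, at 977 nM. The change to compound 3 is fluoro in place of hydroxy on an aromatic carbon, ortho to a methoxy group and meta to a large group.

Going by the values given here, only one measured step bears on this change: a 3.2-fold lower number from compound 1 to compound 2 (0.51 log units; beyond the scatter). That step, hydroxy in place of hydrogen on the same aromatic carbon, was modest but beyond the scatter. Among the compounds with values here, no measured compound carries fluoro, so the data give no direct reading of this replacement and the uncertainty is wide.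

Compound 3 lacks the hydroxy group that distinguishes compound 2 from compound 1, so part of that modest step is expected to be lost, with a higher number in this assay. The expected change is a 1.6-fold higher number from compound 2 to compound 3 (0.21 log units; within the scatter). For compound 3 the estimated value is 1600 nM, with an expected range of 550 nM to 4500 nM.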

Compound 3, concentration for 50% growth inhibition: 6460 nM
For compound 3 the middle estimate is 4.0-fold (0.61 log units) below the measured one; the measured number lies above the stated range.
By their numbers in this assay, from the lowest: compound 2; then compound 1; then compound 3.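

In this assay this aromatic carbon, ortho to a methoxy group and meta to a large group, now responds in both directions, not only to the gain seen with hydroxy. Fluoro in place of hydrogen gives a 2.0-fold higher number from compound 1 to compound 3 (0.31 log units; beyond the scatter) and so moves the read-out the opposite way from hydroxy in place of hydrogen, while fluoro in place of hydroxy gives a 6.6-fold higher number from compound 2 to compound 3 (0.82 log units; beyond the scatter) and spans the whole range of the three compounds. The series therefore runs from hydroxy through hydrogen to fluoro at this one carbon, with the lower number tied so far to hydroxy alone, and nothing available here accounts for that order.

On these data alone, it remains open whether the lower number belongs to hydroxy specifically or would also appear with an amine, a carboxylic acid or a longer chain such as ethoxy on the same carbon. Also open, as far as these compounds go, is whether the same order of hydroxy, hydrogen and fluoro would hold with changes elsewhere on the shared core, since all three compounds carry the same remaining groups.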